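Changing the Amide Group While Keeping the Core Fixed

A few compounds are considered here, and "the series" means these few. Any claim that something is new, unique, unknown or untested is made for them only; others in the source may bear on it.

In a functional assay on the whole organism with Mus musculus as the target, at a dose of 100 mg/kg by the intraperitoneal route (on this read-out lower numbers stand for less inhibition and higher numbers for more inhibition at the one dose given (going by the name of the read-out)), three compounds have been measured:

compound 1, `CN(C)C(=O)/C=C1\CCc2ccc(F)cc21`: 100%
compound 2, `CN(C)C(=O)/C=C1\CCc2c(F)cc(F)cc21`: 100%
compound 3, `NC(=O)/C=C1\CCc2cc(F)c(F)cc21`: 100%

Within the data shown here, all three read-outs stand at the top of the scale, so compound 1 is level with compound 2 and compound 3, and the single one-place step that has been measured, no change at the digits printed from compound 1 to compound 2 (within the scatter), shows nothing beyond the usual scatter. That step concerns fluoro in place of hydrogen on an aromatic carbon, a change on the ring, whereas compound 4, `O=C(/C=C1\CCc2ccc(F)cc21)N1CCCC1`, differs from compound 1 at the amide: pyrrolidin-1-yl in place of dimethylamino on a carbonyl carbon. Among the measured compounds shown here, no measured pair among compounds 1 to 3 alters the group on the carbonyl carbon whose other neighbours are a double-bonded chain carbon, so the measured steps bear on the change to compound 4 only in a general way: they show that variation at the ring of the shared core leaves the number in this assay level. With every measured value already at the top and no step beyond the scatter, the expectation for compound 4 is that it stays where compound 1 is, a step of about a number 3 percentage points lower from compound 1 to compound 4 (within the scatter). Compound 4 is therefore estimated at 97%, with a range from 80% to 100%, the upper end being bounded by the scale itself.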

Compound 4, a percentage reported as inhibition, in the whole organism at one dose (the size of the read-out at that dose, not a potency): 33%
Estimate against measurement, compound 4: 64 percentage points above; the measured number lies below the stated range.
By their numbers in this assay, from the lowest: compound 4; then compounds 1, 2 and 3 (each within the scatter of the next).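

In this assay, pyrrolidin-1-yl in place of dimethylamino on a carbonyl carbon whose other neighbours are a double-bonded chain carbon gives a number 67 percentage points lower from compound 1 to compound 4 (beyond the scatter). Among these compounds, this is the first step to lie beyond the scatter: the only earlier one-place step, the fluoro on an aromatic carbon, gave no change at the digits printed from compound 1 to compound 2 (within the scatter), so the read-out at this dose is not held at the top of the scale by the shared core alone and does respond to the group on the carbonyl carbon. No evidence at hand bears on what lies behind this drop.

Among the compounds shown here, the single step cannot separate the presence of a ring in the entering group from its greater number of heavy atoms, and groups such as diethylamino, azetidin-1-yl, piperidin-1-yl or morpholin-4-yl on the same carbonyl carbon would be needed to tell these apart. It also remains open whether pyrrolidin-1-yl gives a similar drop on the fluoro pattern of compound 2 or compound 3, since the compounds shown carry this group only on the core of compound 1.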